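Methyl in place of chloro: notes on compound 3

A few compounds are considered here, and "the series" means these few. Any claim that something is new, unique, unknown or untested is made for them only; others in the source may bear on it.

Of the compounds shown here, two have been measured so far in an ADME assay for permeability, using PAMPA, with a stated time of 4 h; on this read-out higher numbers stand for higher permeability and lower numbers for lower permeability. Compound 1 `Cc1ccc(Oc2cc3c(cn2)nc(COc2cccc(C(=O)O)c2)n3C)cc1` gives 6.8 10^-6 cm/s, and compound 2 `Cn1c(COc2cccc(C(=O)O)c2)nc2ccc(Oc3cccc(Cl)n3)cc21` gives 7.6 10^-6 cm/s. Among the compounds with values here, compound 2 therefore stands level with compound 1, the only other measured compound, as the two values lie within the scatter of each other.

Compound 3 `Cc1cccc(Oc2ccc3nc(COc4cccc(C(=O)O)c4)n(C)c3c2)n1` is not yet measured. It keeps the structure of compound 2 except for one substitution, in which 6-chloropyridin-2-yl becomes 6-methylpyridin-2-yl: methyl in place of chloro on an aromatic carbon. The methyl takes the place of the chloro on an aromatic carbon, next to the ring nitrogen.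

Within the data shown here, compound 1 and compound 2 differ in more than one place, so the series offers no measured example of this substitution. Among the measured compounds shown here, the close agreement of their values is the only guide available, and it is weak evidence. No shift beyond the scatter is therefore expected in this assay, and no direction can be firmly assigned. The estimated step of a 1.2-fold lower number from compound 2 to compound 3 (0.07 log units; within the scatter) is expected to remain within the scatter. For compound 3 the expected value is 6.5 10^-6 cm/s, with an estimated range of 3.2 10^-6 cm/s to 13 10^-6 cm/s.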

Compound 3, apparent permeability: 2.7 10^-6 cm/s
For compound 3 the middle estimate is 2.4-fold (0.38 log units) above the measured one; the measured number lies below the stated range.
By their numbers in this assay, from the lowest: compound 3; then compounds 1 and 2 (each within the scatter of the next).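

At this aromatic carbon next to the ring nitrogen, methyl in place of chloro gives a 2.8-fold lower number from compound 2 to compound 3 (0.45 log units; beyond the scatter) in this assay, so this read-out responds to a change of a single heavy atom here, with no change in the counted hydrogen-bond donors, hydrogen-bond acceptors or net charge. Within the data shown here, this is the first measured one-place step, and as a single pair it describes this position on this scaffold, not the substitution in general. The data at hand offer nothing that bears on the origin of the step.

Only chloro and methyl are shown at this carbon, so it remains open whether the step tracks the arrival of methyl or the departure of chloro, and hydrogen, fluoro, methoxy or nitrile at the same place would help to separate those two readings. Also open, as far as these compounds go, is whether the same substitution elsewhere on the 6-chloropyridin-2-yl ring, or on a different core such as that of compound 1, gives a step of similar size and direction.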